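Swapping the urea chain for a thiazolylmethyl group

This account rests on a few compounds, and the source may have more. Where it says the series, first, only, none or still open, it means among the compounds named here.

Compounds 1, 2 and 3 share one core and differ only in the group on a nitrogen on an aromatic ring. Compound 1 `Cc1nc(NC(C)(C)C)nc(N[C@@H]2C[C@H](CO)[C@@H](O)[C@H]2O)c1-c1nc2ccccc2s1` gives 12000 nM in an ADME assay on cells (Homo sapiens) for cytotoxicity, read by polymerase chain reaction, with a stated time of 3 days; on this read-out higher numbers stand for lower toxicity in this test and lower numbers for higher toxicity in this test. Compound 2 `Cc1nc(NCCOC(C)C)nc(N[C@@H]2C[C@H](CO)[C@@H](O)[C@H]2O)c1-c1nc2ccccc2s1` gives 8000 nM in this assay, and the step of a 1.5-fold lower number from compound 1 to compound 2 (0.18 log units; within the scatter) is small. Compound 3 `Cc1nc(NCCNC(=O)NC(C)(C)C)nc(N[C@@H]2C[C@H](CO)[C@@H](O)[C@H]2O)c1-c1nc2ccccc2s1` reaches only a limit of the test, > 25000 nM in this assay, so no number is known for it. Compared with its two neighbours, the steps of an at least 2.0-fold higher number from compound 1 to compound 3 (0.31 log units; beyond the scatter) and an at least 3.1-fold higher number from compound 2 to compound 3 (0.49 log units; beyond the scatter) are at least modest, and the limit of > 25000 nM in this assay, at which 1 of the 3 values shown sits, marks the top of what the test reports.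

Compound 4 `Cc1nc(NCc2nccs2)nc(N[C@@H]2C[C@H](CO)[C@@H](O)[C@H]2O)c1-c1nc2ccccc2s1` has not yet been measured. It differs from compound 3 in one place: 1,3-thiazol-2-yl in place of (((tert-butyl)carbamoyl)amino)methyl on a saturated chain carbon bound to a nitrogen on an aromatic ring. The group that enters is smaller than the group that leaves and carries no hydrogen-bond donor, which brings the side chain closer in size to those of compound 1 and compound 2. The two measured steps that bear on this position both ran upward to the limit when the longer urea chain was put in; reversing that change is expected to bring the number back down, so for compound 4 a step of about an at least 1.7-fold lower number from compound 3 to compound 4 (0.25 log units; that floor lies within the scatter) is estimated. Compound 4 is therefore expected to give roughly 14000 nM in this assay, between 6000 nM and 30000 nM.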

Compound 4, half-maximal cytotoxic concentration: 23000 nM
Beside the measured number, compound 4's estimate is 1.6-fold (0.22 log units) below it; measured number inside the range.
By their numbers in this assay, from the lowest: compounds 2, 1 and 4 (each within the scatter of the next, the first and the last beyond it). At a limit, above all of these: compound 3.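

The result shows that the urea is not needed for a high number at this position in this assay: with 1,3-thiazol-2-yl, which has 5 heavy atoms and 0 hydrogen-bond donors, in place of isopropoxymethyl on a saturated chain carbon bound to a nitrogen on an aromatic ring, the step is a 2.9-fold higher number from compound 2 to compound 4 (0.46 log units; beyond the scatter). Neither the step of a 1.9-fold higher number from compound 1 to compound 4 (0.28 log units; within the scatter) nor the step of an at least 1.0-fold lower number from compound 3 to compound 4 (0.03 log units; that floor lies within the scatter) separates the groups concerned, so (1,3-thiazol-2-yl)methyl cannot be told apart from tert-butyl here, and the loss of the urea chain shows no change that can be read. Compound 3 stays at a limit of the test, not at a number: the limit of > 25000 nM in this assay, at which 1 of the 4 values shown sits.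

The compounds shown leave open how far the true value of compound 3 lies from that limit, and with it the real size of its step to compound 4. They also leave open whether the thiazole ring itself matters, which a phenyl ring, a pyridine ring or a primary amine on a longer chain, set on the same nitrogen, would begin to show.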